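This account rests on a few compounds, and the source may have more. Where it says the series, first, only, none or still open, it means among the compounds named here.

Three sulfonamides were tested in an assay on CHO cells for binding affinity to integrin alpha-1 (Homo sapiens), read by WST assay, with a stated time of 2 h, tested at 50 uM; a lower number here means less inhibition, a higher number more inhibition at the concentration tested (going by the name of the read-out). Compound 1 `Cc1ccc(S(=O)(=O)Nc2ccc(C(=O)c3ccccc3)cc2)cc1` gives 35%, and compound 2 `Cc1ccc(S(=O)(=O)Nc2cccc(C(=O)c3ccccc3)c2)cc1` gives 34%; the difference between the two cores is not broken down here. Compound 3 `O=C(c1ccccc1)c1cccc(NS(=O)(=O)c2ccc(Br)cc2)c1` gives 92%. From compound 2 to compound 3 the change is bromo in place of methyl on an aromatic carbon, and it brings a number 58 percentage points higher from compound 2 to compound 3 (beyond the scatter). Compound 4 `O=C(c1ccccc1)c1ccc(NS(=O)(=O)c2ccc(Br)cc2)cc1` carries the same change on the core of compound 1, namely (bromo in place of methyl on an aromatic carbon). Because compound 3 stands at 92% after that change, and because compound 2 sits within the scatter of compound 1 at 35%, a step of similar size is expected, estimated as a number 53 percentage points higher from compound 1 to compound 4 (beyond the scatter) in this assay. Compound 4 is therefore expected to give about 88%, with the estimate spanning 62% to 100%.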

Compound 4, a percentage reported as inhibition, at one concentration (the size of the read-out at that concentration, not a potency): 34%
Beside the measured number, compound 4's estimate is 54 percentage points above it, outside the stated range (below it).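

In this assay, the change from 4-methylphenyl to 4-bromophenyl does not carry from one core to the other: the same change on two cores in this assay, a number 58 percentage points higher (beyond the scatter) from compound 2 to compound 3 and a number 1 percentage points lower (within the scatter) from compound 1 to compound 4, 59 percentage points apart, beyond the scatter of two such steps. Here the swap brings a number 1 percentage points lower from compound 1 to compound 4 (within the scatter), so the large step seen earlier cannot be read as a general result of placing bromo on the sulfonyl-bearing ring across this series. Among the compounds shown here, with only one pair on each core, the result shows that the size of the step differs between these two cores, but it does not show what in the cores accounts for that gap or how the change would behave on a further core. The compounds shown leave open whether a group such as chloro, an amine or a carboxylic acid in that place would give a large step on either core.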